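The source may report more compounds than this note shows. Statements on the series, on what has been measured and on what is new or still open speak of the compounds shown alone.

This account follows one step in a small set of compounds. Compound 1 `COc1cc2sc(Nc3ccccc3)c(C#N)c2cc1OC` gives 77% in a functional assay on HUVEC cells (Homo sapiens), read by fluorescence and microscopy, with a stated time of 6 h, tested at 10 uM; a lower number here means a stronger effect, a higher number a weaker effect of the compound at the concentration tested. Compound 2 `N#Cc1c(Nc2cccc(O)c2)sc2ccccc12` gives 0% in this assay, and compound 3 `N#Cc1c(Nc2ccc(N)cc2)sc2ccccc12` gives 1% in this assay. Among these three numbers compound 3 stands second highest; its nearest neighbour is compound 2, whose number is lower by an amount within the usual scatter, while compound 1 lies furthest away, with a number higher by an amount well beyond the scatter. Compound 4 `COc1ccc(Nc2sc3ccccc3c2C#N)cc1` has not yet been measured in this assay. It differs from compound 3 in one place: methoxy in place of amino on an aromatic carbon. No step between measured compounds carries this same change, so the expectation rests only on the numbers shown. Because compound 3 gives 1% and compound 2 gives 0%, both near the bottom of the scale, the change is expected to be a small move toward a higher number, perhaps not beyond the scatter. The expected step is a number 14 percentage points higher from compound 3 to compound 4 (beyond the scatter). Compound 4 is estimated at 15%, with a range from 0% to 50%.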

Compound 4, a percentage reported as activity, at one concentration (the size of the read-out at that concentration, not a potency): 57%
Estimate against measurement, compound 4: 42 percentage points below; measured number above the stated range.
By their numbers in this assay, from the lowest: compounds 2 and 3 (each within the scatter of the next); then compound 4; then compound 1.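

Replacing amino with methoxy on an aromatic carbon, para to a large group, gives a number 56 percentage points higher from compound 3 to compound 4 (beyond the scatter) in this assay, so the read-out at this concentration is sensitive to the group at this position. The change lowers the count of hydrogen-bond donors and raises the count of heavy atoms, while the count of acceptors and the net charge stay the same, but this single step cannot separate these differences. No measurement shown bears on why the number moves.

As far as these compounds go, it remains open whether a dimethylamino group, an ethoxy group or a carboxylic acid at this position would give a number nearer that of compound 3 or that of compound 4. From the compounds shown here alone, it is also open whether the same change would produce a step of similar size on the core of compound 1.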